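The source may hold more compounds than are shown below. What is called first, only, known or untested is meant among the compounds shown, and "the series" means these compounds.

Working notes on the series.

Three compounds carry the same core and differ only in the group on a saturated chain carbon bound to an aromatic nitrogen. Compound 1 `Nc1nc(O)c2c(n1)n(C1OC(CO)[C@@H](O)[C@H]1O)c(=O)n2C/C=C/c1ccccc1` gives 103 uM in a functional assay (B cells) with Mus musculus as the target; a higher number here means that more compound is needed for the effect, a lower number that less compound is needed. Compound 2 `Nc1nc(O)c2c(n1)n(C1OC(CO)[C@@H](O)[C@H]1O)c(=O)n2CC(O)CO` gives 45 uM in this assay, the step of a 2.3-fold lower number from compound 1 to compound 2 (0.36 log units; beyond the scatter). Compound 3 `N#Cc1ccc(Cn2c(=O)n(C3OC(CO)[C@@H](O)[C@H]3O)c3nc(N)nc(O)c32)cc1` gives 15 uM in this assay, the lowest of the three numbers; the steps to it are a 6.9-fold lower number from compound 1 to compound 3 (0.84 log units; beyond the scatter) and a 3.0-fold lower number from compound 2 to compound 3 (0.48 log units; beyond the scatter).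

Compound 4 `Cn1c(=O)n(C2OC(CO)[C@@H](O)[C@H]2O)c2nc(N)nc(O)c21` is not yet measured. The change from compound 3 is hydrogen in place of 4-cyanophenyl on a saturated chain carbon bound to an aromatic nitrogen.

Within the data shown here, no measured step removes the substituent entirely, so the two steps into compound 3 are the only guide: both show that the 4-cyanophenyl group sits at the favourable end of what has been tried, and that the other groups tried give higher numbers. Taking away the whole group is expected to reverse that gain, with a step at least the size of a 3.0-fold lower number from compound 2 to compound 3 (0.48 log units; beyond the scatter) and plausibly more. Compound 4 is therefore expected to give 70 uM in this assay, within 25 uM to 200 uM, meaning an expected step of a 4.7-fold higher number from compound 3 to compound 4 (0.67 log units; beyond the scatter).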

Compound 4, concentration for half-maximal effect: 10 uM
The estimate for compound 4 lay 7.0-fold (0.85 log units) above the measured number; the measured number lies below the stated range.
By their numbers in this assay, from the lowest: compounds 4 and 3 (each within the scatter of the next); then compound 2; then compound 1.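

In this assay the 4-cyanophenyl group proves not to be needed at this position: its removal gives a 1.5-fold lower number from compound 3 to compound 4 (0.18 log units; within the scatter) and so separates the 4-cyanobenzyl of compound 3 from the methyl of compound 4 by no readable margin. The other two groups now stand as costs against plain hydrogen on a saturated chain carbon bound to an aromatic nitrogen, with a 4.5-fold lower number from compound 2 to compound 4 (0.65 log units; beyond the scatter) for 1,2-dihydroxyethyl and a 10-fold lower number from compound 1 to compound 4 (1.01 log units; beyond the scatter) for 2-phenylethenyl. No measurement at hand accounts for these differences.

The compounds shown leave open whether a short chain such as ethyl or propyl, or a chain ending in an amine or a carboxylic acid, would stay level with compound 4 or move away from it. They also leave open whether an unsubstituted benzyl group would match the 4-cyanobenzyl of compound 3.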